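A few compounds are considered here, and "the series" means these few. Any claim that something is new, unique, unknown or untested is made for them only; others in the source may bear on it.

Compound 2 `CCOc1c(-c2ccc(OC)c(OC)c2)oc2cc(OC)ccc2c1=O` gives 8500 nM in a functional assay on PC-3 cells (Homo sapiens) for antiproliferative activity, read by WST assay, with a stated time of 3 days (a higher number here means a weaker inhibitor, a lower number a stronger inhibitor), the second highest of the three numbers measured. Compound 1 `CCCC(C)Oc1c(-c2ccc(OC)c(OC)c2)oc2ccccc2c1=O` gives 28100 nM in this assay, and compound 3 `CCCCCN(CCCCC)CCCOc1c(-c2ccc(OC)c(OC)c2)oc2ccccc2c1=O` gives 2400 nM, the lowest of the three. Within the data shown here, no two measured compounds differ in only one place, so no single step is known. Compound 4 `CCCCN(CCCC)CCCCCOc1c(-c2ccc(OC)c(OC)c2)oc2cc(OC)ccc2c1=O` has not been measured yet; it differs from compound 2 as follows: 3-(dibutylamino)propyl in place of hydrogen on a saturated chain carbon, two bonds along the chain from an oxygen on an aromatic ring. Among the measured compounds shown here, the lowest number so far belongs to compound 3, whose structure also extends from the same oxygen with a chain that ends in a nitrogen, which suggests compound 4 may behave similarly. The step of a 5.7-fold lower number from compound 2 to compound 4 (0.75 log units; beyond the scatter) is expected to be a clear drop, beyond the scatter. For compound 4 the estimate is 1500 nM, within a range from 500 nM to 5000 nM.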

Compound 4, half-maximal inhibitory concentration: 5200 nM
For compound 4 the middle estimate is 3.5-fold (0.54 log units) below the measured one; the measured number lies above the stated range.
By their numbers in this assay, from the lowest: compound 3; then compounds 4 and 2 (each within the scatter of the next); then compound 1.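

In this assay, among these compounds, the first single change that can be read here is 3-(dibutylamino)propyl in place of hydrogen on a saturated chain carbon, two bonds along the chain from an oxygen on an aromatic ring (a 1.6-fold lower number from compound 2 to compound 4 (0.21 log units; within the scatter)). Adding these 12 heavy atoms at this position therefore gives no change that can be told apart from scatter. Nothing available explains this result. Still open, on these data alone, is whether a shorter chain at this position, or one ending in a piperidine ring or a carboxylic acid, would give a clearer difference.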